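The compounds below may be only part of what the source reports. "The series", "measured", "known", "first", "only" and "open" are said of these compounds alone.

Measured so far in a functional assay for inhibition, with Homo sapiens as the target; a lower number here means tighter binding, a higher number weaker binding:
- compound 1, `O=C(O)CC/C=C\CC1COC(c2ccc(Cl)cc2Cl)OC1c1cccnc1`: 891 nM
- compound 2, `O=C(O)CC/C=C\CC1COC(c2cccc3ccccc23)OC1c1cccnc1`: 631 nM

Going by the values given here, compound 1 has the higher of the two numbers, and its only neighbour is compound 2, where the change of naphthalen-1-yl in place of 2,4-dichlorophenyl on a saturated ring carbon gave a 1.4-fold lower number from compound 1 to compound 2 (0.15 log units; within the scatter). Compound 3, `CC(C)(Sc1ccccc1)C1OCC(C/C=C\CCC(=O)O)C(c2cccnc2)O1`, is not yet measured; it differs from compound 1 by a group of 10 heavy atoms (9 carbon, 1 sulfur; one six-membered aromatic ring of carbon only) in place of a group of 8 heavy atoms (6 carbon, 2 chlorine; one six-membered aromatic ring of carbon only), on a saturated ring carbon. Among the compounds with values here, the one measured step, from compound 1 to compound 2, also swaps the group on that saturated ring carbon and stayed within the scatter, so no step beyond the scatter is expected here either. Compound 3 is therefore estimated at 800 nM, with a range of 250 nM to 2500 nM, an expected step of a 1.1-fold lower number from compound 1 to compound 3 (0.05 log units; within the scatter).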

Compound 3, dissociation constant: 200 nM
The estimate for compound 3 lay 4.0-fold (0.60 log units) above the measured number; measured number below the stated range.
By their numbers in this assay, from the lowest: compound 3; then compounds 2 and 1 (each within the scatter of the next).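

In this assay, the saturated ring carbon between two ring oxygen atoms proved sensitive to the group it carries. The swap of 2,4-dichlorophenyl for naphthalen-1-yl had stayed within the scatter, but the sulfur-containing group gave a 4.5-fold lower number from compound 1 to compound 3 (0.65 log units; beyond the scatter) and a 3.2-fold lower number from compound 2 to compound 3 (0.50 log units; beyond the scatter) at this same position. No measurement shown here accounts for this difference.

The compounds leave open whether the sulfur or the phenyl group carries the step. They also leave open whether an amine or a longer alkyl chain on this ring carbon would keep the lower number.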